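The source may report more compounds than this note shows. Statements on the series, on what has been measured and on what is new or still open speak of the compounds shown alone.

In an in vivo ADME assay on the whole organism (Cavia porcellus) (on this read-out higher numbers stand for a longer-lived compound and lower numbers for a shorter-lived compound), three compounds of one series have been measured so far. Compound 1 `CC(NC(=O)c1ccc(C(=N)N)cc1)C(C)(C)C(=O)N1CCC(CC(=O)O)CC1` gives 0.883 h, compound 2 `CCCCC(NC(=O)c1ccc(C(=N)N)cc1)C(C)(C)C(=O)N1CCC(CC(=O)O)CC1` gives 1.03 h, and compound 3 `CC(NC(=O)c1ccc(C(=N)N)cc1F)C(C)(C)C(=O)N1CCC(CC(=O)O)CC1` gives 1.4 h. These three values lie within the scatter of one another, so compound 3 cannot be ranked against the other two.

Compound 4 `CCCCC(NC(=O)c1ccc(C(=N)N)cc1F)C(C)(C)C(=O)N1CCC(CC(=O)O)CC1` differs from compound 3 in one place: propyl in place of hydrogen on a saturated chain carbon, two bonds along the chain from an amide-type nitrogen. This puts propyl in place of hydrogen on a saturated chain carbon, two bonds along the chain from an amide-type nitrogen. The same replacement has been measured once, without the fluoro group, as a 1.2-fold higher number from compound 1 to compound 2 (0.07 log units; within the scatter), within the scatter. The fluoro in place of hydrogen on an aromatic carbon gave a 1.6-fold higher number from compound 1 to compound 3 (0.20 log units; within the scatter), also within the scatter, and compound 4 retains that group.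

Among the measured compounds shown here, with only one measured example of the propyl replacement, no change beyond the scatter is expected in this assay. The expected step is a 1.1-fold higher number from compound 3 to compound 4 (0.06 log units; within the scatter). Compound 4 is therefore estimated at 1.6 h, with an expected range of 0.9 h to 2.8 h.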

Compound 4, half-life: 1.3 h
Estimate against measurement, compound 4: 1.2-fold (0.09 log units) above; measured number inside the range.
By their numbers in this assay, from the lowest: compounds 1, 2, 4 and 3 (each within the scatter of the next).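

In this assay, among the compounds shown here, the propyl replacement on a saturated chain carbon, two bonds along the chain from an amide-type nitrogen, has now been read on a second core, the one carrying fluoro, and gives a 1.1-fold lower number from compound 3 to compound 4 (0.03 log units; within the scatter), so the single earlier reading is no longer alone and the two agree within the scatter: the same change on two cores in this assay, a 1.2-fold higher number (0.07 log units; within the scatter) from compound 1 to compound 2 and a 1.1-fold lower number (0.03 log units; within the scatter) from compound 3 to compound 4, 1.3-fold (0.10 log units) apart, within the scatter of two such steps The fluoro replacement has likewise been read on a second core, the one carrying propyl, and gives a 1.3-fold higher number from compound 2 to compound 4 (0.10 log units; within the scatter), which also agrees with its earlier reading: the same change on two cores in this assay, a 1.6-fold higher number (0.20 log units; within the scatter) from compound 1 to compound 3 and a 1.3-fold higher number (0.10 log units; within the scatter) from compound 2 to compound 4, 1.3-fold (0.10 log units) apart, within the scatter of two such steps On both cores, then, neither change separates its pair of compounds beyond the scatter.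

On these data alone, whether a longer chain, a phenyl ring or a chain ending in an amine at this carbon would shift the half-life beyond the scatter remains open. As far as these compounds go, it is equally open whether chloro or methoxy on the aromatic carbon would do so.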